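Notes on the series: from compound 2 to compound 3

The source may report more compounds than this note shows. Statements on the series, on what has been measured and on what is new or still open speak of the compounds shown alone.

Measured in a functional assay on HT-29 cells (Homo sapiens) for cytotoxicity; a lower number here means that less compound is needed, a higher number that more compound is needed for the effect:
- compound 1 `COc1cc(/C=C\c2ccc(C(C)(C)C)cc2)cc(OC)c1OC` gives 8.8 uM
- compound 2 `COc1cc(/C=C\c2ccc(C(C)C)cc2)cc(OC)c1OC` gives 2.4 uM

Compound 2 holds the lower number of the two measured compounds, and its gap to compound 1 lies beyond the scatter. The next structure, compound 3 `CCCOc1ccc(/C=C\c2cc(OC)c(OC)c(OC)c2)cc1`, is still unmeasured and carries propoxy in place of isopropyl on an aromatic carbon. Going by the values given here, only one measured step bears on this change: a 3.7-fold lower number from compound 1 to compound 2 (0.56 log units; beyond the scatter). That modest step, with hydrogen in place of methyl, altered the same group that compound 3 replaces. Among the compounds with values here, it did not exchange isopropyl for propoxy, and no measured compound carries propoxy, so the guidance is weak. A further modest step toward a lower number in this assay is expected, although a result within the scatter of compound 2 remains possible. For compound 3 the estimated value is 1 uM, with an expected range from 0.2 uM to 5 uM. The expected change is therefore a 2.4-fold lower number from compound 2 to compound 3 (0.38 log units; beyond the scatter).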

Compound 3, concentration for half-maximal effect: 2.8 uM
Estimate against measurement, compound 3: 2.8-fold (0.45 log units) below; the range from low to high includes it.
By their numbers in this assay, from the lowest: compounds 2 and 3 (each within the scatter of the next); then compound 1.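

In this assay, propoxy in place of isopropyl on this aromatic carbon gives a 1.2-fold higher number from compound 2 to compound 3 (0.07 log units; within the scatter), so the position accepts a group that brings an oxygen and a hydrogen-bond acceptor without a change that can be told from the scatter. Propoxy in place of tert-butyl gives a 3.1-fold lower number from compound 1 to compound 3 (0.50 log units; beyond the scatter), which means that compound 1 now stands apart from two different groups rather than from isopropyl alone, and among the three compounds shown, tert-butyl is the only group whose number lies beyond the scatter of the others. No supporting data accompany these numbers to account for the close match of isopropyl and propoxy or for the gap to tert-butyl.

Open, on these data alone, is whether the match with propoxy extends to other ethers on the same carbon, such as methoxy, ethoxy or the longer butoxy, or whether the number depends on the length of the chain. Also open is how this position responds to a hydroxyl group or an amine, since all three groups shown carry no hydrogen-bond donor.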